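The source may hold more compounds than are shown below. What is called first, only, known or untested is meant among the compounds shown, and "the series" means these compounds.

Of the compounds shown here, two have so far been tested in an ADME assay on HMEC-1 cells (Homo sapiens) for antiproliferative activity, read by cell counting, with a stated time of 5 days; a higher number here means a weaker inhibitor, a lower number a stronger inhibitor. Compound 1 `COc1ccc(-c2cc(-c3ccc(OC)cc3)on2)cc1` reaches only the limit of the assay, > 100000 nM, so no number is known for it. Among the compounds with values here, compound 2 `Oc1ccc(-c2cc(-c3ccc(O)cc3)on2)cc1` gives 6300 nM in this assay, and this is the only numeric value available. The other result sits at the limit of > 100000 nM in this assay, at which 1 of the 2 values shown sits. Compound 3 `CCc1c(-c2ccc(O)cc2)noc1-c1ccc(O)cc1` has not yet been tested. It differs from compound 2 by ethyl in place of hydrogen on an aromatic carbon. Within the data shown here, no step between two measured compounds exists here to show how such a change behaves. The expectation is that the step in this assay is modest, and it is estimated as a 1.6-fold lower number from compound 2 to compound 3 (0.20 log units; within the scatter). Compound 3 is therefore expected to give about 4000 nM in this assay, within an estimated range from 800 nM to 20000 nM.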

Compound 3, half-maximal inhibitory concentration: 9700 nM
The estimate for compound 3 lay 2.4-fold (0.38 log units) below the measured number; measured number inside the range.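

Placing ethyl in place of hydrogen on an aromatic carbon, next to two ring atoms that each bear a 4-hydroxyphenyl group, gives a 1.5-fold higher number from compound 2 to compound 3 (0.19 log units; within the scatter). Within the data shown here, compounds 1 and 2 both carry hydrogen on this carbon, so this is the first sign that a substituent can sit there while the result in this assay stays within the usual scatter. No measurement shown here explains this outcome. Still open, going by these compounds, is whether a longer chain, an amine or a carboxylic acid on the same carbon would leave the number equally undisturbed. Also open, on these data alone, is how ethyl would behave on the core of compound 1, whose result of > 100000 nM is a limit of the assay and not a number.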